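Fluoro for hydrogen on the aniline ring of compound 1

This account rests on a few compounds, and the source may have more. Where it says the series, first, only, none or still open, it means among the compounds named here.

Measured compounds:
- compound 1, `O=C(Nc1ccc(Oc2ccnc3[nH]ccc23)cc1)c1cn(-c2ccc(Cl)cc2)c2ccccc2c1=O`: 250 nM
- compound 2, `O=C(Nc1ccc(Oc2ccnc3[nH]ccc23)cc1)c1cn(-c2ccc(C(F)(F)F)cc2Cl)c2ccccc2c1=O`: "not determined" (no result reported)

Among the compounds with values here, compound 1 is the only compound with a number; in a functional assay on HepG2 cells (Homo sapiens) for inhibition, read by MTT assay, with a stated time of 72 h (on this read-out higher numbers stand for weaker inhibition and lower numbers for stronger inhibition), compound 1 gives 250 nM. Compound 2 carries a different group on the indole nitrogen, and in this assay compound 2 gives "not determined" (no result reported), so it offers no comparison. Compound 3, `O=C(Nc1ccc(Oc2ccnc3[nH]ccc23)c(F)c1)c1cn(-c2ccc(Cl)cc2)c2ccccc2c1=O`, differs from compound 1 by fluoro in place of hydrogen on an aromatic carbon. Within the data shown here, no measured pair shows such a step here, so there is no precedent to lean on; the expected step from compound 1 to compound 3 is no change at the digits printed from compound 1 to compound 3 (within the scatter), within the scatter. For compound 3 an estimate of 250 nM is expected, between 100 nM and 650 nM.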

Compound 3, half-maximal inhibitory concentration: 380 nM
Estimate against measurement, compound 3: 1.5-fold (0.18 log units) below, within the range that was stated.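

In this assay, within the data shown here, fluoro in place of hydrogen on an aromatic carbon gives a 1.5-fold higher number from compound 1 to compound 3 (0.18 log units; within the scatter), the first step that can be read, as compound 2 has no number to compare. At this position, ortho to a large group and meta to a large group, a single fluoro therefore leaves the read-out within the usual scatter. Nothing measured here gives a reason for this result. On these data alone, whether chloro, methoxy or an amine at the same carbon would also stay within the scatter remains open.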